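This account rests on a few compounds, and the source may have more. Where it says the series, first, only, none or still open, it means among the compounds named here.

Compound 1, `OB1OCc2ccc(-n3cc(Sc4ccc(F)cc4)c4ccccc43)cc21`. In an ADME assay on L929 cells (Mus musculus) for cytotoxicity, read by resazurin assay, with a stated time of 72 h (a higher number here means a weaker inhibitor, a lower number a stronger inhibitor), compound 1 gives > 10 ug/mL, which is a limit of the assay and not a number.
Compound 2, `O=C(c1ccn(-c2ccc3c(c2)B(O)OC3)c1)c1ccc(Cl)cc1Cl`. In this assay compound 2 gives > 10 ug/mL, again a limit of the assay rather than a measured number.

Compound 2 therefore stands at the edge of what this assay can report, and it shares that position with every other value in the set: the limit of > 10 ug/mL in this assay, at which 2 of the 2 values shown sit. On these numbers nothing separates compound 2 from compound 1; both only show that the cytotoxicity of each is weaker than the assay records.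

Compound 3, `O=C(c1ccc(O)cc1)c1ccn(-c2ccc3c(c2)B(O)OC3)c1`, differs from compound 2 in one place: 4-hydroxyphenyl in place of 2,4-dichlorophenyl on a carbonyl carbon. For the measured compounds named here, no pair of measured compounds here differs in a single place, so no measured step shows how such an exchange moves the read-out. With both known values sitting at the limit, the step that the limit leaves unreadable from compound 2 to compound 3 is expected to be none beyond the usual scatter. Compound 3 is estimated to give 15 ug/mL, with a range from 7 ug/mL to 40 ug/mL, and the assay may once more report only its limit.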

Compound 3, half-maximal inhibitory concentration: > 10 ug/mL
Compound 3 was reported as a limit (the forecaster's own chance of this, stated with the estimate: 70%); the middle value lies beyond the limit too.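

Compound 2 and compound 3 both end at the limit of this assay, so swapping 2,4-dichlorophenyl for 4-hydroxyphenyl gives no step that can be read, and all values here are limits rather than numbers: the limit of > 10 ug/mL in this assay, at which 3 of the 3 values shown sit.

On these data alone, how far any of the three compounds lies past that limit remains open, and so does whether this exchange changes the result in this assay at all.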